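The compounds below may be only part of what the source reports. "The series", "measured", "known", "first", "only" and "open" are said of these compounds alone.

Of the compounds shown here, three have been measured in an assay on isolated protein for displacement of a labelled ligand from Bile acid receptor (Homo sapiens), read by scintillation proximity assay and radioligand binding; on this read-out lower numbers stand for stronger inhibition and higher numbers for weaker inhibition. Compound 1 `Cc1cc(OCc2c(-c3cc[nH]c(=O)c3Cl)noc2C(C)C)ccc1-c1ccc2c(C(=O)O)cn(C)c2c1` gives 1100 nM. Compound 2 `COc1ccccc1-c1noc(C(C)C)c1COc1ccc(/C=C/c2cccc(C(=O)O)c2)c(Cl)c1` gives 250 nM. Compound 3 `Cc1cc(OCc2c(-c3c(Cl)ccc(=O)n3C)noc2C(C)C)ccc1-c1ccc2c(C(=O)O)cn(C)c2c1` gives 235 nM, the lowest number of the three; against compound 2 it lies within the usual scatter, so the two cannot be told apart, while against compound 1 the gap is real, with a 4.7-fold lower number from compound 1 to compound 3 (0.67 log units; beyond the scatter).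

Compound 4 `COc1ccc(Cl)c(-c2noc(C(C)C)c2COc2ccc(-c3ccc4c(C(=O)O)cn(C)c4c3)c(C)c2)n1` has not yet been measured. It holds the same atoms as compound 3, joined differently: a group of 9 heavy atoms (6 carbon, 1 nitrogen, 1 oxygen, 1 chlorine; one six-membered aromatic ring with 1 hetero atom) in place of a group of 9 heavy atoms (6 carbon, 1 nitrogen, 1 oxygen, 1 chlorine; one six-membered aromatic ring with 1 hetero atom), on an aromatic carbon. The new group, 3-chloro-6-methoxypyridin-2-yl, sits on an aromatic carbon of the five-membered aromatic ring with 1 nitrogen and 1 oxygen, two ring bonds from the ring atom that bears the isopropyl group.

For the measured compounds named here, only one measured step touches this part of the molecule, the one from compound 1 to compound 3, and it changed the number by a modest amount. Going by the values given here, no measured pair shows the exact rearrangement made here. Compound 2 carries a methoxy-bearing six-membered ring at the same place, on a different core, and its number is close to that of compound 3. Compound 4 is therefore expected to come out near compound 3, with a 1.3-fold lower number from compound 3 to compound 4 (0.12 log units; within the scatter), and its expected value is 180 nM, in a range from 40 nM to 800 nM.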

Compound 4, half-maximal inhibitory concentration: 310 nM
Compound 4: middle estimate off by 1.7-fold (0.24 log units), on the low side, and the stated range covers the measured number.
By their numbers in this assay, from the lowest: compounds 3, 2 and 4 (each within the scatter of the next); then compound 1.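

In this assay, rearranging the same atoms on this aromatic carbon into 3-chloro-6-methoxypyridin-2-yl gives a 1.3-fold higher number from compound 3 to compound 4 (0.12 log units; within the scatter), so the two compounds cannot be told apart. The group that leaves carries a double bond outside its aromatic ring and the group that enters carries none, so in this pair that double bond is not needed to hold the number in this range. The gap to compound 1 also remains real, with a 3.5-fold lower number from compound 1 to compound 4 (0.55 log units; beyond the scatter), which means two differently joined groups at this position now stand apart from the group of compound 1, and no supporting data are available to explain these results.

The compounds shown leave open whether the methoxy of the new group could give way to an ethoxy or an amine, or its chlorine to a fluorine or a nitrile, with the number holding in this range. They also do not tell whether this pyridine group would behave the same way with a cyclopropyl group in place of the isopropyl group on the five-membered ring.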